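This account rests on a few compounds, and the source may have more. Where it says the series, first, only, none or still open, it means among the compounds named here.

Measured compounds in a functional assay on HT-29 cells (Homo sapiens) for antiproliferative activity, read by sulforhodamine B assay, with a stated time of 48 h; on this read-out lower numbers stand for stronger inhibition and higher numbers for weaker inhibition:
- compound 1, `O=C1NCCN1c1ccc(S(=O)(=O)Nc2ccc(F)cc2)cc1`: 370 nM
- compound 2, `Cc1cc(C)cc(NS(=O)(=O)c2ccc(N3CCNC3=O)cc2)c1`: 82 nM
- compound 3, `Cc1cccc(NS(=O)(=O)c2ccc(N3CCNC3=O)cc2)c1C`: 190 nM

Compound 1 stands at the highest number of the three. Its step to compound 2 is a 4.5-fold lower number from compound 1 to compound 2 (0.65 log units; beyond the scatter); its step to compound 3 is a 1.9-fold lower number from compound 1 to compound 3 (0.29 log units; within the scatter), which stays within the scatter. Between the two dimethyl compounds the step is a 2.3-fold higher number from compound 2 to compound 3 (0.36 log units; beyond the scatter).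

Compound 4, `CCCCCCOc1ccc(NS(=O)(=O)c2ccc(N3CCNC3=O)cc2)cc1`, differs from compound 1 by hexyloxy in place of fluoro on an aromatic carbon. Going by the values given here, no measured step replaces the fluoro with an alkoxy chain, so none bears directly on it. The steps from compound 1 to compound 2 and from compound 1 to compound 3 show only that replacing the fluorophenyl on the sulfonamide nitrogen with a dimethylphenyl gave lower or unchanged numbers in this assay. On that basis a small step toward a lower number is expected, of a size that may stay within the scatter, so the estimate for compound 4 is 220 nM, with a range from 70 nM to 700 nM. This estimate corresponds to an expected step of a 1.7-fold lower number from compound 1 to compound 4 (0.23 log units; within the scatter).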

Compound 4, half-maximal inhibitory concentration: > 1000 nM
Compound 4: a limit, no number; the forecaster's own chance of this, stated with the estimate: 5%; middle value at least 4.5-fold (0.65 log units) away from the limit.
By their numbers in this assay, from the lowest: compound 2; then compounds 3 and 1 (each within the scatter of the next). At a limit, above all of these: compound 4.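

In this assay, going by these compounds alone, hexyloxy in place of fluoro on an aromatic carbon, para to a large group, gives an at least 2.7-fold higher number from compound 1 to compound 4 (0.43 log units; beyond the scatter), the only step from compound 1 in this set that goes to a higher number. The earlier steps shown here, which swapped the whole 4-fluorophenyl for a dimethylphenyl, gave no sign that a change on this aryl group could cost activity, so this position does not accept every group. Compound 4 stands at a limit and not at a number: the limit of > 1000 nM in this assay, at which 1 of the 4 values shown sits.

Going by these compounds, how far compound 4 lies past that limit stays unknown, so the size of the step has only a lower bound. Also open, on these data alone, is whether a methoxy or ethoxy group, an amine or a carboxylic acid at this position would stay near compound 1, and so whether the chain or its oxygen goes with the higher number.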